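From a Nitro Group to Bromine: Expected Tolerance

The compounds below may be only part of what the source reports. "The series", "measured", "known", "first", "only" and "open" are said of these compounds alone.

Compound 1, `COc1ccc(-c2cnc(NC(=O)C3CCCC3)n2C)cc1`, gives > 100000 nM in a toxicity assay on THP-1 cells (Homo sapiens) for inhibition; a lower number here means that less compound is tolerated, a higher number that more compound is tolerated; this is a limit of the assay, not a number.
Compound 2, `COc1ccc(-c2cnc(NC(=O)c3ccn[nH]3)n2C)cc1`, gives > 100000 nM in this assay; again this is a limit.
Compound 3, `COc1ccc(-c2cnc(NC(=O)c3cccc([N+](=O)[O-])c3)n2C)cc1`, gives > 100000 nM in this assay; this too is a limit.

All three compounds share one core and differ only in the group attached to the carbonyl carbon. Within the data shown here, the one change between measured compounds, 1H-pyrazol-5-yl in place of cyclopentyl, gives a step that the two limits leave unreadable from compound 1 to compound 2. Among the measured compounds shown here, compound 3 therefore stands nowhere in particular among the numbers: because of the limit of > 100000 nM in this assay, at which 3 of the 3 values shown sit, no measured compound is separated from another, and the cytotoxicity of all three lies beyond what the assay can report.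

The next compound, compound 4, `COc1ccc(-c2cnc(NC(=O)c3cccc(Br)c3)n2C)cc1`, differs from compound 3 by bromo in place of nitro on an aromatic carbon. For the measured compounds named here, no measured step bears directly on this change, and the single step available is itself unreadable. With every value at the limit, no step beyond the scatter is expected in this assay. Compound 4 is therefore expected to give 150000 nM, with a range from 50000 nM to 500000 nM, most likely again as a limit. The expected step is a step that the limit leaves unreadable from compound 3 to compound 4.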

Compound 4, half-maximal cytotoxic concentration: > 100000 nM
Compound 4 gave a limit, no number; the forecaster's own chance of this, stated with the estimate: 85%; the middle value does not contradict the limit.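

No step to compound 4 from compound 1, compound 2 or compound 3 can be read, because all four values are limits of the assay, not numbers: the limit of > 100000 nM in this assay, at which 4 of the 4 values shown sit.

The compounds shown leave open which group on the carbonyl carbon, if any, would bring the cytotoxic concentration within what this assay can report.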